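A few compounds are considered here, and "the series" means these few. Any claim that something is new, unique, unknown or untested is made for them only; others in the source may bear on it.

Measured compounds:
compound 1, `COc1cccc(C(=O)Oc2ccc3c(=O)c(-c4cc(OC)c(OC)cc4OC)coc3c2)c1`, in a functional assay on HUVEC cells (Homo sapiens) for antiproliferative activity, read by MTT assay, with a stated time of 24 h (a lower number here means a stronger inhibitor, a higher number a weaker inhibitor), compound 1 gives > 10000 nM
compound 2, `COc1cc(OC)c(-c2coc3cc(OCc4ccc(F)cc4)ccc3c2=O)cc1OC`, in this assay compound 2 gives > 10000 nM
compound 3, `COc1cc(OC)c(-c2coc3cc(OCc4cccc(Cl)c4)ccc3c2=O)cc1OC`, in this assay compound 3 gives > 10000 nM

Each of these values is a limit of this assay rather than a number. Compound 1 therefore stands only at that limit. The steps a step that the two limits leave unreadable from compound 1 to compound 2 and a step that the two limits leave unreadable from compound 1 to compound 3 cannot be sized, and the same holds for a step that the two limits leave unreadable from compound 2 to compound 3, because of the limit of > 10000 nM in this assay, at which 3 of the 3 values shown sit.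

Compound 4, `COc1cc(OC)c(-c2coc3cc(OCc4cccc(Br)c4)ccc3c2=O)cc1OC`, has not been measured. It differs from compound 1 as follows: 3-bromobenzyl in place of (3-methoxyphenyl)carbonyl on an oxygen on an aromatic ring. The steps from compound 1 to compound 2 and from compound 1 to compound 3 bear on it most directly, each replacing the same group with a benzyl group, and each ends at the limit. The closest comparison is compound 3, which carries 3-chlorobenzyl where compound 4 carries 3-bromobenzyl. No readable step exists, so no direction can be expected beyond the scatter, and compound 4 is expected to remain at the limit as well.

Compound 4 is estimated at 15000 nM, with a range from 5000 nM to 50000 nM, which corresponds to an expected step that the limit leaves unreadable from compound 1 to compound 4.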

Compound 4, half-maximal inhibitory concentration: > 10000 nM
Compound 4: a limit, no number; the forecaster's own chance of this, stated with the estimate: 85%; the middle value does not contradict the limit.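

Within the data shown here, compound 4 gives only a limit in this assay, so no step among compound 1, compound 2, compound 3 and compound 4 can be read: the limit of > 10000 nM in this assay, at which 4 of the 4 values shown sit.

The compounds shown leave open whether any of them differs from another in this assay, and which group on the oxygen would give a readable value.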